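Chloro for Nitro on the Aryl Ring of Compound 3

The source may hold more compounds than are shown below. What is called first, only, known or untested is meant among the compounds shown, and "the series" means these compounds.

For the measured compounds named here, compound 3 `CCOC(=O)c1c(-c2ccc([N+](=O)[O-])cc2)n(-c2ccc(C(=O)NNC(=O)CO[N+](=O)[O-])cc2)[nH]c1=O` carries the highest of the three numbers so far in a functional assay on the whole organism (strain Wistar) for inhibition, with Rattus norvegicus as the target, read by paw edema, with a stated time of 1 h, at a dose of 6 mg/kg by the oral route (a lower number here means less inhibition, a higher number more inhibition at the dose given (going by the name of the read-out)), giving 27.8%, while compound 1 `O=C(CO[N+](=O)[O-])NNC(=O)c1ccc(-n2[nH]c(=O)cc2-c2ccc([N+](=O)[O-])cc2)cc1` gives 23.6% and compound 2 `O=C(CO[N+](=O)[O-])NNC(=O)c1ccc(-n2[nH]c(=O)cc2-c2ccccc2O)cc1` gives 23%, both within the scatter of compound 3. Compound 4 `CCOC(=O)c1c(-c2ccc(Cl)cc2)n(-c2ccc(C(=O)NNC(=O)CO[N+](=O)[O-])cc2)[nH]c1=O` differs from compound 3 by chloro in place of nitro on an aromatic carbon. Going by the values given here, the one measured step that alters the same aromatic ring, a number 0.6 percentage points lower from compound 1 to compound 2 (within the scatter), stayed within the scatter; the other, a number 4.2 percentage points higher from compound 1 to compound 3 (within the scatter), concerns a different position and also stayed within the scatter. One therefore expects no step beyond the scatter in this assay for compound 4, estimated as a number 0.8 percentage points lower from compound 3 to compound 4 (within the scatter). Compound 4 is expected at 27%, with a range from 18% to 36%.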

Compound 4, a percentage reported as inhibition, in the whole organism at one dose (the size of the read-out at that dose, not a potency): 3.2%
Compound 4: the middle estimate sits 23.8 percentage points above what was measured, outside the stated range (below it).
By their numbers in this assay, from the lowest: compound 4; then compounds 2, 1 and 3 (each within the scatter of the next).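

In this assay, chloro in place of nitro gives a number 24.6 percentage points lower from compound 3 to compound 4 (beyond the scatter), the only step beyond the scatter among the compounds shown, so the group on this aromatic carbon, para to a large group, can move the number. The earlier change on this ring, a number 0.6 percentage points lower from compound 1 to compound 2 (within the scatter), had not shown this. Nothing measured here accounts for the drop.

From the compounds shown here alone, whether the same change would have the same size without the ethoxycarbonyl group stays open. So does what an amine or a methoxy group would give in place of nitro.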